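A few compounds are considered here, and "the series" means these few. Any claim that something is new, unique, unknown or untested is made for them only; others in the source may bear on it.

In a functional assay on K562 cells (Homo sapiens) for cytotoxicity (a lower number here means a stronger inhibitor of growth, a higher number a weaker inhibitor of growth), compound 1 (`OCCC#Cc1ccccc1C#Cc1ccccc1`) gives 11000 nM and compound 2 (`OCCCCC#Cc1ccccc1C#Cc1ccccn1`) gives 29000 nM. Compound 2 therefore holds the higher of the two numbers, making it the weaker growth inhibitor of the pair, and its gap to compound 1 lies beyond the scatter. Going by the values given here, the two compounds differ in more than one place, so this gap cannot be assigned to any single change, and no measured single-place step is available as a guide.

Compound 3 (`OCCCCC#Cc1ccccc1C#Cc1ccc(O)cc1`) keeps the rest of compound 2 and carries 4-hydroxyphenyl in place of pyridin-2-yl on a triple-bonded carbon. Among the compounds with values here, the only guide is indirect: the one measured compound with a ring of carbon only at that place, compound 1 at 11000 nM, has the lower number. A small move toward a lower number in this assay is therefore expected, of about the size of the scatter, and it may not clear it. The estimated change is a 1.8-fold lower number from compound 2 to compound 3 (0.26 log units; within the scatter). For compound 3 the estimated value is 16000 nM, with an expected range of 6000 nM to 40000 nM.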

Compound 3, concentration for 50% growth inhibition: 20400 nM
Compound 3: middle estimate off by 1.3-fold (0.11 log units), on the low side; low and high end bracket the measured number.
By their numbers in this assay, from the lowest: compounds 1, 3 and 2 (each within the scatter of the next, the first and the last beyond it).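

In this assay, the series gains its first readable single-place step, a 1.4-fold lower number from compound 2 to compound 3 (0.15 log units; within the scatter), with 4-hydroxyphenyl in place of pyridin-2-yl on a triple-bonded carbon. At this place, a six-membered aromatic ring with one hetero atom and no hydrogen-bond donor can be exchanged for a ring of carbon only that carries a hydroxyl and one hydrogen-bond donor without a change that clears the scatter, so compound 2 and compound 3 cannot be put in order. No measurement is at hand that bears on the reason for this outcome.

Still open, on these data alone, is what an unsubstituted phenyl, a 4-aminophenyl or a 4-carboxyphenyl would give at this place on the chain of compound 2, which would show whether the hydroxyl and the ring nitrogen each matter on their own. Going by these compounds alone, the contribution of the hydroxyl-bearing chain also remains unresolved, as compound 1 and compound 2 differ in more than one place and no single-place step isolates that chain.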